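The compounds below may be only part of what the source reports. "The series", "measured", "known", "first", "only" and "open" are said of these compounds alone.

Measured compounds:
compound 1 `Cc1ccc(NC(=S)NC(=O)c2ccc(OCc3ccc(C(F)(F)F)cc3)cc2)cc1-c1nc2ccccc2[nH]1` — 6500 nM
compound 2 `Cc1ccc(NC(=S)NC(=O)c2ccc(OCc3cccc(C(F)(F)F)c3)cc2)cc1-c1nc2ccccc2[nH]1` — 5210 nM
compound 3 `Cc1ccc(NC(=S)NC(=O)c2ccc(OCc3cccc(F)c3)cc2)cc1-c1nc2ccccc2[nH]1` — > 100000 nM

In a functional assay on MGC-803 cells (Homo sapiens) for inhibition, read by MTT assay, with a stated time of 48 h (a lower number here means a stronger inhibitor, a higher number a weaker inhibitor), compound 1 gives 6500 nM and compound 2 gives 5210 nM. For compound 3 only a limit is recorded, > 100000 nM, which is a limit of the assay and not a number; it sits at the boundary described as the limit of > 100000 nM in this assay, at which 1 of the 3 values shown sits. Compound 3 is therefore the only one of the three without a measured value, and it stands at the weak end of what is shown.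

Compound 4 `Cc1ccc(NC(=S)NC(=O)c2ccc(OCc3ccc(F)cc3)cc2)cc1-c1nc2ccccc2[nH]1` differs from compound 3 by 4-fluorophenyl in place of 3-fluorophenyl on a saturated chain carbon bound to an oxygen on an aromatic ring. Going by the values given here, two measured steps bear on this. The corresponding move of the trifluoromethyl group between the same two positions gave a 1.2-fold lower number from compound 1 to compound 2 (0.10 log units; within the scatter), a step within the scatter. The exchange of the group itself, fluoro for trifluoromethyl, gave an at least 19-fold higher number from compound 2 to compound 3 (1.28 log units; beyond the scatter), and the combined change gave an at least 15-fold higher number from compound 1 to compound 3 (1.18 log units; beyond the scatter). Since the positional move alone produced no step beyond the scatter, compound 4 is expected to remain near the limit, with an estimated step of a number no higher from compound 3 to compound 4 (the limit leaves the size open) in this assay. Compound 4 is thus estimated at 100000 nM, within the range 25000 nM to 300000 nM.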

Compound 4, half-maximal inhibitory concentration: 2810 nM
Compound 4: the middle estimate sits 36-fold (1.55 log units) above what was measured; the whole stated range lies above it.
By their numbers in this assay, from the lowest: compounds 4, 2 and 1 (each within the scatter of the next, the first and the last beyond it). At a limit, above all of these: compound 3.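

In this assay, the choice of 4-fluorophenyl over 3-fluorophenyl on a saturated chain carbon bound to an oxygen on an aromatic ring proves decisive, giving an at least 35-fold lower number from compound 3 to compound 4 (1.55 log units; beyond the scatter), although the corresponding exchange with trifluoromethyl gave only a 1.2-fold lower number from compound 1 to compound 2 (0.10 log units; within the scatter). Fluoro on the phenyl ring is therefore compatible with micromolar inhibition, with a 1.9-fold lower number from compound 2 to compound 4 (0.27 log units; within the scatter) and a 2.3-fold lower number from compound 1 to compound 4 (0.36 log units; beyond the scatter). Exchanging trifluoromethyl for fluoro thus has no single outcome, its result depending on where the group sits: the same change on two cores in this assay, an at least 19-fold higher number (1.28 log units; beyond the scatter) from compound 2 to compound 3 and a 2.3-fold lower number (0.36 log units; beyond the scatter) from compound 1 to compound 4, at least 44-fold (1.64 log units) apart, beyond the scatter of two such steps.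

From the compounds shown here alone, for compound 3, > 100000 nM is a limit of the assay and not a number, so the full size of its steps stays open. Also open, going by these compounds, is whether 4-chlorophenyl, an amine or carboxylic acid on this phenyl ring, or a longer chain in place of the saturated chain carbon would keep this level of inhibition.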